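This account rests on a few compounds, and the source may have more. Where it says the series, first, only, none or still open, it means among the compounds named here.

Measured so far in a functional assay on Jurkat cells (Homo sapiens) for antiproliferative activity, read by MTT assay; a higher number here means a weaker inhibitor, a lower number a stronger inhibitor:
Compound 1, `COc1ccccc1/C=C1\CCc2cc(OC)c(OC)cc2C1=O`, returns only a limit, > 50000 nM.
Compound 2, `COc1cccc(/C=C2\CCc3cc(OC)c(OC)cc3C2=O)c1`, gives 5000 nM.

Compound 2 therefore holds the only actual number shown. Compound 3, `COc1ccc(OC)c(/C=C2\CCc3cc(OC)c(OC)cc3C2=O)c1`, differs from compound 2 by methoxy in place of hydrogen on an aromatic carbon. Among the measured compounds shown here, the single measured step, an at least 10-fold lower number from compound 1 to compound 2 (1.00 log units; beyond the scatter), moved a methoxy group from one ring carbon to another rather than adding a second one, so it offers only loose guidance; a step of modest size at most, or none beyond the scatter, is expected. Compound 3 is expected to sit at a 1.7-fold lower number from compound 2 to compound 3 (0.22 log units; within the scatter), which gives an estimate of 3000 nM, between 800 nM and 15000 nM.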

Compound 3, half-maximal inhibitory concentration: 11000 nM
Compound 3: the middle estimate sits 3.7-fold (0.56 log units) below what was measured; the measured number falls inside the stated range.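

Putting methoxy in place of hydrogen on the aromatic carbon ortho to a large group and para to a methoxy group brings a 2.2-fold higher number from compound 2 to compound 3 (0.34 log units; beyond the scatter) in this assay, so here the added group costs a modest amount of activity. The same kind of change starting from the other methoxy isomer gives an at least 4.5-fold lower number from compound 1 to compound 3 (0.65 log units; beyond the scatter), so its direction depends on the starting compound. That step is open-ended because compound 1 gives only a limit: the limit of > 50000 nM in this assay, at which 1 of the 3 values shown sits.

As far as these compounds go, whether a hydroxyl group or an amine at this position would behave like methoxy remains open.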